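A few compounds are considered here, and "the series" means these few. Any claim that something is new, unique, unknown or untested is made for them only; others in the source may bear on it.

Measured compounds in a functional assay on A549 cells (Homo sapiens) for antiproliferative activity, read by MTT assay, with a stated time of 72 h; on this read-out higher numbers stand for weaker inhibition and lower numbers for stronger inhibition:
compound 1, `COc1cc(-n2ncnc2-c2ccc(F)cc2)cc(OC)c1OC`: > 10000 nM, a limit of the assay.
compound 2, `COc1cc(-c2ncnn2-c2ccc(Cl)cc2Cl)cc(OC)c1OC`: > 10000 nM, a limit of the assay.
compound 3, `COc1cc(-c2ncnn2-c2ccc([N+](=O)[O-])cc2)cc(OC)c1OC`: > 10000 nM, a limit of the assay.

Within the data shown here, compound 1 stands at the limit of > 10000 nM in this assay, at which 3 of the 3 values shown sit, so it gives no number of its own, only a limit, and no measured step separates it from any other compound. Compound 4, `COc1cc(-n2ncnc2-c2cccc(Cl)c2)cc(OC)c1OC`, differs from compound 1 by 3-chlorophenyl in place of 4-fluorophenyl on an aromatic carbon. With nothing but limits on record, the account expects no step beyond the usual scatter in this assay from this change, and gives no direction. The estimate for compound 4 is 15000 nM, with a range of 5000 nM to 50000 nM. This estimate means an expected step that the limit leaves unreadable from compound 1 to compound 4, most likely reported as a limit again.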

Compound 4, half-maximal inhibitory concentration: > 10000 nM
Compound 4: a limit, no number (the forecaster's own chance of this, stated with the estimate: 75%); the middle value is on the limit's open side.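

Compound 4 gives only a limit, > 10000 nM, so no step between compound 1 and compound 4 can be read: the limit of > 10000 nM in this assay, at which 4 of the 4 values shown sit.

The compounds shown leave open how 3-chlorophenyl and 4-fluorophenyl compare in this assay, and none of them gives a number.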